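Swapping the piperidine nitrogen substituent of compound 2 for ethylsulfonyl

This account rests on a few compounds, and the source may have more. Where it says the series, first, only, none or still open, it means among the compounds named here.

Two compounds share the core and differ only in the group on the piperidine nitrogen. Compound 1 `COCCOC(=O)N1CCC(Oc2ncnc3c2CCN3c2ccc(S(C)(=O)=O)cc2F)CC1` carries a carbamate there and in a functional assay on CHO-K1 cells for agonist activity at Glucose-dependent insulinotropic receptor (Homo sapiens), read by a luciferase reporter, with a stated time of 5 h (on this read-out lower numbers stand for an effect already at smaller amounts and higher numbers for an effect only at larger amounts of compound), compound 1 gives 316 nM. Compound 2 `CS(=O)(=O)c1ccc(N2CCc3c(OC4CCN(C(=S)Sc5ccccc5)CC4)ncnc32)c(F)c1` carries a dithiocarbamate instead, and in this assay compound 2 gives 12.6 nM, the lowest of the two numbers; the step of a 25-fold lower number from compound 1 to compound 2 (1.40 log units; beyond the scatter) is large and beyond the scatter.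

Compound 3 `CCS(=O)(=O)N1CCC(Oc2ncnc3c2CCN3c2ccc(S(C)(=O)=O)cc2F)CC1` is the next variation at the same position. The change from compound 2 to compound 3 is a group of 5 heavy atoms (2 carbon, 2 oxygen, 1 sulfur; no ring) in place of a group of 9 heavy atoms (7 carbon, 2 sulfur; one six-membered aromatic ring of carbon only), on an amine nitrogen in a ring. Going by the values given here, the only measured step that bears on it is the one from compound 1 to compound 2, where a group without a ring gave way to the larger ring-bearing group and the number fell sharply. Compound 3 now loses that ring-bearing group for a smaller one without a ring, so the step is expected to run the other way, probably toward the level of compound 1, as a 12-fold higher number from compound 2 to compound 3 (1.08 log units; beyond the scatter). Compound 3 is therefore estimated at 150 nM in this assay, within 40 nM to 600 nM.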

Compound 3, half-maximal effective concentration: 1580 nM
The estimate for compound 3 lay 11-fold (1.02 log units) below the measured number, outside the stated range (above it).
By their numbers in this assay, from the lowest: compound 2; then compound 1; then compound 3.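

In this assay, replacing the group of compound 2 with ethylsulfonyl on the amine nitrogen in the ring gives a very large loss (a 130-fold higher number from compound 2 to compound 3 (2.10 log units; beyond the scatter)), which shows how much the number at this position depends on the group that leaves. The two groups without a ring also differ from each other (a 5.0-fold higher number from compound 1 to compound 3 (0.70 log units; beyond the scatter)), so the absence of a ring does not alone fix the number, and the change from (2-methoxyethoxy)carbonyl to ethylsulfonyl matters in its own right. Nothing available here accounts for either difference, so the result stands as an observation without an explanation.

The compounds shown leave open whether the low number of compound 2 goes with its six-membered aromatic ring, with its two sulfur atoms, or only with the two together, since that group differs from the others in all of these at once. As far as these compounds go, a phenylsulfonyl group or a phenoxycarbonyl group would keep the ring without the thiocarbonyl, while a methylthio-thiocarbonyl group would keep both sulfur atoms without the ring, and how either would read here remains unknown.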